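The source may report more compounds than this note shows. Statements on the series, on what has been measured and on what is new or still open speak of the compounds shown alone.

Measured so far in a physicochemical assay for lipophilicity, read by HPLC, measured as octanol-water partition, at pH 7.2; on this read-out higher numbers stand for higher lipophilicity and lower numbers for lower lipophilicity
- compound 1 `O=C(Nc1ccc(F)c(C(F)(F)F)c1)Nc1cnccn1` gives 3
- compound 2 `O=C(Nc1ccc(F)c(C(F)(F)F)c1)Nc1ccccn1` gives 3.7

Of these two, compound 2 stands higher in this assay at 3.7 and is the starting point here. Compound 3 `Cc1cc(NC(=O)Nc2ccc(F)c(C(F)(F)F)c2)on1` has not been measured yet. It differs from compound 2 by one change: 3-methyl-1,2-oxazol-5-yl in place of pyridin-2-yl on an amide-type nitrogen with 3-methyl-1,2-oxazol-5-yl in place of pyridin-2-yl on an amide-type nitrogen. For the measured compounds named here, the only measured step that bears on this is a number 0.70 log units higher from compound 1 to compound 2 (beyond the scatter) for another ring exchange at that nitrogen, and it is modest. Going by the values given here, no measured compound carries the entering group, so a step of modest size downward is only expected, namely a number 0.40 log units lower from compound 2 to compound 3 (beyond the scatter) as estimated. Compound 3 is estimated at 3.3 with 2.8 to 3.8 as its expected range.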

Compound 3, distribution coefficient: 3.2
For compound 3 the middle estimate is 0.10 log units above the measured one, and the stated range covers the measured number.
By their numbers in this assay, from the lowest: compounds 1 and 3 (each within the scatter of the next); then compound 2.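

In this assay the position on the amide-type nitrogen also takes a five-membered ring, and 3-methyl-1,2-oxazol-5-yl in place of pyridin-2-yl gives a number 0.50 log units lower from compound 2 to compound 3 (beyond the scatter). Against pyrazin-2-yl the same group gives a number 0.20 log units higher from compound 1 to compound 3 (within the scatter), so these two rings are not told apart here, and pyridin-2-yl alone stands apart from both. Nothing measured here accounts for these steps. The compounds shown leave open what the methyl on the entering ring contributes, and how an open group such as an amine or a longer chain would read at this nitrogen in this assay.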